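A few compounds are considered here, and "the series" means these few. Any claim that something is new, unique, unknown or untested is made for them only; others in the source may bear on it.

Measured so far: compound 2 `C=C1C(=O)[C@]23C[C@@]1(O)CC[C@H]2c1ccc(O)c(C)c1[C@@H]3Cn1cc(-c2ccc(Br)cc2)nn1`, 1140 nM; compound 3 `C=C1C(=O)[C@]23C[C@@]1(O)CC[C@H]2c1ccc(OS(=O)(=O)c2ccc(C)cc2)c(C)c1[C@@H]3Cn1cc(-c2ccc(Br)cc2)nn1`, 1630 nM; compound 1 `C=C1C[C@]23C[C@@]1(O)CC[C@H]2c1cc(Br)c(O)c(C)c1[C@@H]3Cn1cc(-c2ccccn2)nn1`, > 20000 nM.

In a functional assay on A549 cells (Homo sapiens) for cytotoxicity, read by MTT assay, with a stated time of 4 days (on this read-out higher numbers stand for weaker inhibition and lower numbers for stronger inhibition), compound 2 gives 1140 nM, the lowest of the two numbers shown. Compound 3 sits nearest, with a 1.4-fold higher number from compound 2 to compound 3 (0.16 log units; within the scatter). In this assay compound 1 reaches only a limit, > 20000 nM. Compound 1 differs from compound 2 in several places at once, so its result says nothing about any single change. Compound 4 `C=C1C(=O)[C@]23C[C@@]1(O)CC[C@H]2c1ccc(O)c(C)c1[C@@H]3Cn1cc(-c2ccc(OC)cc2)nn1` is not yet measured; it differs from compound 2 by methoxy in place of bromo on an aromatic carbon. No measured step touches that ring, so nothing shown here tells how large a step to expect in this assay, or in which direction. Among the compounds with values here, the one measured step, from compound 2 to compound 3, altered a different part and stayed within the scatter. Compound 4 is therefore expected to give about 1500 nM, between 500 nM and 5000 nM. This estimate means a 1.3-fold higher number from compound 2 to compound 4 (0.12 log units; within the scatter).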

Compound 4, half-maximal inhibitory concentration: 1250 nM
Compound 4: middle estimate off by 1.2-fold (0.08 log units), on the high side; the measured number falls inside the stated range.
By their numbers in this assay, from the lowest: compounds 2, 4 and 3 (each within the scatter of the next). At a limit, above all of these: compound 1.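

Within the data shown here, replacing 4-bromophenyl with 4-methoxyphenyl gives the only measured step at this ring: this assay shows a 1.1-fold higher number from compound 2 to compound 4 (0.04 log units; within the scatter). At this one position, then, the assay does not separate bromo from methoxy, even though methoxy brings one hydrogen-bond acceptor and bromo brings none. Nothing shown gives a reason for this result. From the compounds shown here alone, both groups carry no net charge, so what an amine or a carboxylic acid would give at this position stays open. So does the result for a longer chain, such as butoxy, in place of methoxy.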